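Chloro Step Carried Over Onto the Triazole Core

The source may hold more compounds than are shown below. What is called first, only, known or untested is meant among the compounds shown, and "the series" means these compounds.

Measured so far:
Compound 1 `Cc1nnc(SCC(=O)N/N=c2/scc(-c3ccccc3)n2-c2ccccc2)s1`: 197 ug/mL
Compound 2 `Cc1nnc(SCC(=O)N/N=c2/scc(-c3ccc(Cl)cc3)n2-c2ccccc2)s1`: 253 ug/mL
Compound 3 `Cn1cnnc1SCC(=O)N/N=c1/scc(-c2ccccc2)n1-c1ccccc1`: 217 ug/mL

All three numbers come from an ADME assay on NIH3T3 cells (Mus musculus) for cytotoxicity, read by MTT assay, with a stated time of 24 h (a higher number here means a weaker inhibitor, a lower number a stronger inhibitor), and they lie close together. Compound 1 gives 197 ug/mL in this assay, compound 2 gives 253 ug/mL and compound 3 gives 217 ug/mL. Compound 2 differs from compound 1 by chloro in place of hydrogen on an aromatic carbon, and that change made a 1.3-fold higher number from compound 1 to compound 2 (0.11 log units; within the scatter). Compound 3 differs from compound 1 by 4-methyl-4H-1,2,4-triazol-3-yl in place of 5-methyl-1,3,4-thiadiazol-2-yl on a sulfur, which made a 1.1-fold higher number from compound 1 to compound 3 (0.04 log units; within the scatter).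

Compound 4 `Cn1cnnc1SCC(=O)N/N=c1/scc(-c2ccc(Cl)cc2)n1-c1ccccc1` is not yet measured. Among the measured compounds shown here, it differs from compound 3 by chloro in place of hydrogen on an aromatic carbon, the same change as the one from compound 1 to compound 2, at the same kind of place. The step expected from this change is a 1.3-fold higher number from compound 3 to compound 4 (0.11 log units; within the scatter), resting on the measured 1.3-fold higher number from compound 1 to compound 2 (0.11 log units; within the scatter) and on the value of compound 3 of 217 ug/mL. Compound 4 is therefore estimated to give 280 ug/mL in this assay, with a likely range from 170 ug/mL to 450 ug/mL. Two examples are too few to call this a rule.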

Compound 4, half-maximal inhibitory concentration: 51.7 ug/mL
The estimate for compound 4 lay 5.4-fold (0.73 log units) above the measured number; the whole stated range lies above it.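

On the core of compound 3, chloro in place of hydrogen gave a 4.2-fold lower number from compound 3 to compound 4 (0.62 log units; beyond the scatter), a lower number and so a stronger effect in this assay, and this step does not match the one seen on the other core: the same change on two cores in this assay, a 1.3-fold higher number (0.11 log units; within the scatter) from compound 1 to compound 2 and a 4.2-fold lower number (0.62 log units; beyond the scatter) from compound 3 to compound 4, 5.4-fold (0.73 log units) apart, beyond the scatter of two such steps

Read the other way, putting 4-methyl-4H-1,2,4-triazol-3-yl in place of 5-methyl-1,3,4-thiadiazol-2-yl gave a 4.9-fold lower number from compound 2 to compound 4 (0.69 log units; beyond the scatter), so this change also depends on what the rest of the compound carries: the same change on two cores in this assay, a 1.1-fold higher number (0.04 log units; within the scatter) from compound 1 to compound 3 and a 4.9-fold lower number (0.69 log units; beyond the scatter) from compound 2 to compound 4, 5.4-fold (0.73 log units) apart, beyond the scatter of two such steps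

The two changes therefore do not simply add up in these four compounds, but a single pair of steps for each change does not show why, or whether the same would hold elsewhere in the series.

The compounds shown leave open whether fluoro, bromo or methoxy at the same place on the phenyl ring would act as chloro does on each core. They also leave open whether an ethyl group in place of the methyl on the triazole would keep the low number of compound 4.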